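The compounds below may be only part of what the source reports. "The series", "measured", "known", "first", "only" and "open" are said of these compounds alone.

Compound 1 `CCCC(Oc1ccc(-n2cc(Cl)cn2)cc1)c1ccc(C(=O)NCCC(=O)O)cc1` is the starting point. In an ADME assay on microsomes from liver (Homo sapiens) for metabolic stability (on this read-out higher numbers stand for fast clearance and lower numbers for slow clearance), compound 1 gives 10 mL/min/kg, the lowest of the two numbers shown. Compound 3 `O=C(O)CCNC(=O)c1ccc(C(Oc2ccc(-n3cc(C(F)(F)F)cn3)cc2)C2CCCC2)cc1` gives 22 mL/min/kg, and an at least 2.7-fold higher number from compound 2 to compound 3 (0.43 log units; beyond the scatter). Compound 2 `CCC(Oc1ccc(-n2cc(C(F)(F)F)cn2)cc1)c1ccc(C(=O)NCCC(=O)O)cc1` sits at < 8 mL/min/kg, which is a limit of the assay rather than a number (the limit of < 8 mL/min/kg in this assay, at which 1 of the 3 values shown sits). Compound 4 `CCCC(Oc1ccc(-n2cc(F)cn2)cc1)c1ccc(C(=O)NCCC(=O)O)cc1` has not yet been measured; it differs from compound 1 by fluoro in place of chloro on an aromatic carbon. For the measured compounds named here, none of the measured steps involves this exchange of halogens, so no measured step bears on it directly. Compound 4 is therefore expected to stay close to compound 1, with no change at the digits printed from compound 1 to compound 4 (within the scatter) not going beyond the scatter. The estimate for compound 4 is 10 mL/min/kg, ranging from 6 mL/min/kg to 17 mL/min/kg.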

Compound 4, clearance: 12 mL/min/kg
Estimate against measurement, compound 4: 1.2-fold (0.08 log units) below, and the stated range covers the measured number.
By their numbers in this assay, from the lowest: compounds 1, 4 and 3 (each within the scatter of the next, the first and the last beyond it). At a limit, below all of these: compound 2.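

For the compounds shown here, the exchange of 4-chloro-1H-pyrazol-1-yl for 4-fluoro-1H-pyrazol-1-yl shows a 1.2-fold higher number from compound 1 to compound 4 (0.08 log units; within the scatter) in this assay and is the first measured step at this place on the five-membered ring. On this read-out, chloro and fluoro here cannot be told apart. Nothing shown explains why these two halogens read alike.

The compounds shown leave open how a nitrile or an amine would read at this place. Trifluoromethyl also stays uncompared with chloro, as compound 1 and compound 2 differ in two places.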